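Nitro in place of carbamoyl on an aromatic carbon

The compounds below may be only part of what the source reports. "The series", "measured", "known", "first", "only" and "open" are said of these compounds alone.

Of the compounds shown here, three sharing one core have numbers so far in a physicochemical assay for solubility, at pH 7.4 (on this read-out lower numbers stand for lower solubility and higher numbers for higher solubility), on this series. Compound 1 (`Cc1cc(NC(=O)Nc2ccc(F)c(F)c2)c2ccccc2n1`) gives 500 nM in this read-out. Compound 2 (`Cc1cc(NC(=O)Nc2ccc(C(F)(F)F)cc2)c2ccccc2n1`) gives 100 nM in the same read-out. Compound 3 (`Cc1cc(NC(=O)Nc2ccccc2C(N)=O)c2ccccc2n1`) gives 200 nM and so stands within the scatter of compound 2, while its number lies under that of compound 1 by more than the scatter.

The next compound, compound 4 (`Cc1cc(NC(=O)Nc2ccccc2[N+](=O)[O-])c2ccccc2n1`), carries nitro in place of carbamoyl on an aromatic carbon, ortho to a large group (nitro in place of carbamoyl on an aromatic carbon). Within the data shown here, no two measured compounds differ in one place only, so nothing yet shows directly what this exchange does in this assay for this series. Among the measured compounds shown here, the only guide is the spread of the values, with compound 2 at 100 nM and compound 1 at 500 nM as its two ends. A small step is expected, with a weak lean toward a lower number and none beyond the scatter. The estimate implies a 1.3-fold lower number from compound 3 to compound 4 (0.12 log units; within the scatter) as an expected move that stays within the scatter. For compound 4 the estimated value in this assay is 150 nM with an expected range from 50 nM to 450 nM across repeated measurements.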

Compound 4, solubility: 200 nM
Beside the measured number, compound 4's estimate is 1.3-fold (0.12 log units) below it; measured number inside the range.
By their numbers in this assay, from the lowest: compounds 2, 3 and 4 (each within the scatter of the next); then compound 1.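

Among these compounds, the first step that differs in one place only reads, in this assay, no change at the digits printed from compound 3 to compound 4 (within the scatter) with nitro in place of carbamoyl on an aromatic carbon, ortho to a large group. The two groups have the same number of heavy atoms but differ in their counts of hydrogen-bond donors and acceptors, and on this pair that difference comes with no step beyond the scatter, so this one exchange at this position leaves the read-out unresolved from its starting point. Nothing measured here speaks to the reason for this result.

From the compounds shown here alone, whether an amine or a carboxylic acid at this position would stand with compound 3 and compound 4 or apart from them stays open, and one pair cannot settle how far the position tolerates other exchanges. Also open, going by these compounds, is whether nitro in place of carbamoyl would read the same on a ring that carries the trifluoromethyl of compound 2 or the fluorines of compound 1, since each of those compounds differs from compound 3 in more than one place.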